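Thiophen-2-yl in place of thiophen-3-yl from a limit value

The compounds below may be only part of what the source reports. "The series", "measured", "known", "first", "only" and "open" are said of these compounds alone.

Compound 1 `COc1ncnc2c1c(-c1ccsc1)cn2[C@@H]1O[C@H](CO)[C@@H](O)[C@H]1O` gives 140 nM in a functional assay on HCT-116 cells (Homo sapiens), read by MTT assay, with a stated time of 72 h; a higher number here means a weaker inhibitor, a lower number a stronger inhibitor. Compound 2 `CN(C)c1ncnc2c1c(-c1ccsc1)cn2[C@@H]1O[C@H](CO)[C@@H](O)[C@H]1O` reaches only the limit > 20000 nM in this assay. Compound 3 `CNc1ncnc2c1c(-c1ccsc1)cn2[C@@H]1O[C@H](CO)[C@@H](O)[C@H]1O` likewise stops at the limit > 20000 nM in this assay. The two measured steps, an at least 140-fold higher number from compound 1 to compound 2 (2.15 log units; beyond the scatter) and an at least 140-fold higher number from compound 1 to compound 3 (2.15 log units; beyond the scatter), both change the group on another aromatic carbon and both end at the limit of > 20000 nM in this assay, at which 2 of the 3 values shown sit. Compound 4 `CN(C)c1ncnc2c1c(-c1cccs1)cn2[C@@H]1O[C@H](CO)[C@@H](O)[C@H]1O` differs from compound 2 by thiophen-2-yl in place of thiophen-3-yl on an aromatic carbon. Among the measured compounds shown here, no measured step touches this change, so nothing anchors its size or direction. Since compound 2 already sits at the limit, only a large drop in number would produce a readable value. Compound 4 is expected to remain near the limit, with an estimated 20000 nM and a range from 4000 nM to 60000 nM. The expected step of a number no higher from compound 2 to compound 4 (the limit leaves the size open) is thus taken as unreadable rather than real.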

Compound 4, half-maximal inhibitory concentration: > 20000 nM
Compound 4 was reported as a limit; the forecaster's own chance of this, stated with the estimate: 75%; the middle value lies on the limit itself.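

Among the compounds shown here, compound 2 and compound 4 both stop at a limit in this assay, so no step between them can be read. The compounds shown leave open what thiophen-2-yl in place of thiophen-3-yl does in a compound with a readable value, such as compound 1.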